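The source may report more compounds than this note shows. Statements on the series, on what has been measured and on what is new or still open speak of the compounds shown alone.

Three compounds have so far been measured in an assay on isolated protein for displacement of a labelled ligand from melanin-concentrating hormone receptor 1 (Homo sapiens); a lower number here means a stronger inhibitor, a higher number a weaker inhibitor:

compound 1, `CC(C)N(C)c1ccc2cc(NC(=O)CCc3ccc(C(F)(F)F)cc3)ccc2n1`, 2 nM
compound 2, `CN(c1ccc2cc(NC(=O)CCc3ccc(C(F)(F)F)cc3)ccc2n1)C1CCCC1`, 2 nM
compound 3, `CC(=O)NC1CCN(c2ccc3cc(NC(=O)CCc4ccc(C(F)(F)F)cc4)ccc3n2)C1`, 5 nM

Compound 1 stands level with compound 2 at the digits shown, the two of them together holding the lowest numbers of the three, while compound 3 lies furthest off: a 2.5-fold higher number from compound 1 to compound 3 (0.40 log units; beyond the scatter).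

Compound 4, `O=C(CCc1ccc(C(F)(F)F)cc1)Nc1ccc2nc(N3CC4CC3CO4)ccc2c1`, has not yet been measured. It differs from compound 1 in one place: a group of 7 heavy atoms (5 carbon, 1 nitrogen, 1 oxygen; 2 five-membered non-aromatic rings with 1 hetero atom each) in place of a group of 5 heavy atoms (4 carbon, 1 nitrogen; no ring), on an aromatic carbon.

Going by the values given here, two measured steps bear on this change. The first, no change at the digits printed from compound 1 to compound 2 (within the scatter), shows that exchanging one acyclic substituent on that nitrogen for another leaves the number where it was. The second, a 2.5-fold higher number from compound 1 to compound 3 (0.40 log units; beyond the scatter), shows that putting a ring-containing amine in place of the acyclic amine costs a modest amount. The group entering in compound 4 is, like that of compound 3, a ring-containing amine, so a modest rise is expected, of about a 2.0-fold higher number from compound 1 to compound 4 (0.30 log units; within the scatter). Compound 4 is therefore estimated at 4 nM, with a likely range from 1.5 nM to 12 nM.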

Compound 4, half-maximal inhibitory concentration: 13 nM
Beside the measured number, compound 4's estimate is 3.3-fold (0.51 log units) below it; the measured number lies above the stated range.
By their numbers in this assay, from the lowest: compounds 1 and 2 (each within the scatter of the next); then compound 3; then compound 4.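

The position on the aromatic carbon does not treat all ring-containing amines alike in this assay: the group with two five-membered non-aromatic rings gives a 6.5-fold higher number from compound 1 to compound 4 (0.81 log units; beyond the scatter), and likewise a 6.5-fold higher number from compound 2 to compound 4 (0.81 log units; beyond the scatter), even though the groups of compound 2 and compound 4 hold the same count of heavy atoms. The change also outruns the larger ring-containing group of compound 3, with a 2.6-fold higher number from compound 3 to compound 4 (0.41 log units; beyond the scatter), so among these four compounds the number does not rise with the heavy-atom count of the group. Nothing available explains this rise.

The compounds shown leave open how much of the rise goes with the ring oxygen and how much with the second ring, as compound 4 brings in both at once. A plain pyrrolidin-1-yl group and a morpholin-4-yl group in this place would bear on that question.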